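The source may report more compounds than this note shows. Statements on the series, on what has been measured and on what is new or still open speak of the compounds shown alone.

Measured compounds:
compound 1 `O=C1O/C(=C\Cn2cc(Br)c(=O)[nH]c2=O)C(OCc2ccccc2)=C1OCc1ccccc1` — 30000 nM
compound 2 `O=C1O/C(=C\Cn2cnc3c(-n4cccc4)ncnc32)C(OCc2ccccc2)=C1OCc1ccccc1` — > 100000 nM (a limit of the assay, not a number)

In a functional assay on HeLa cells (Homo sapiens) for inhibition (on this read-out higher numbers stand for weaker inhibition and lower numbers for stronger inhibition), compound 1 gives 30000 nM. Among the measured compounds shown here, compound 1 carries the only number reported so far in this assay. For compound 2 this assay reports only a limit, > 100000 nM, at which one of the two values sits (the limit of > 100000 nM in this assay, at which 1 of the 2 values shown sits). For the measured compounds named here, no step between two measured compounds exists in this set, so nothing yet shows how a single change on the shared core moves the read-out.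

Compound 3 `O=C1O/C(=C\Cn2cc(F)c(=O)[nH]c2=O)C(OCc2ccccc2)=C1OCc1ccccc1` is to be measured in this assay. It differs from compound 1 as follows: fluoro in place of bromo on an aromatic carbon. The change swaps one halogen for another of the same count of heavy atoms at the same place, with no change in donors, acceptors or charge.

Nothing in the set measures such a swap. The step from compound 1 to compound 3 is expected to be small, of the order of the scatter or a little toward weaker inhibition, estimated as a 1.5-fold higher number from compound 1 to compound 3 (0.18 log units; within the scatter). Compound 3 is therefore expected to give about 45000 nM in this assay, between 12000 nM and 150000 nM.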

Compound 3, half-maximal inhibitory concentration: 40000 nM
Compound 3: middle estimate off by 1.1-fold (0.05 log units), on the high side, and the stated range covers the measured number.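

In this assay, among the compounds shown here, the first single-place comparison gives a 1.3-fold higher number from compound 1 to compound 3 (0.12 log units; within the scatter), for fluoro in place of bromo on an aromatic carbon. For the compounds shown here, at this position of the six-membered aromatic ring with 2 nitrogen, the read-out therefore does not separate the two halogens, which the earlier compounds, differing from each other in more than one place, could not show. Nothing on hand bears on why the two halogens cannot be told apart here.

The comparison covers only these two halogens at one position, so it cannot say whether the read-out at this place responds to any substituent at all, and a methyl, an amine, a nitrile or a carboxylic acid in place of the halogen would test that. Going by these compounds alone, the effect of single changes elsewhere on the shared core also stays open, for example an amine or a longer chain in place of the benzyl ethers, since no step yet reaches those parts of the molecule.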